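The source may report more compounds than this note shows. Statements on the series, on what has been measured and on what is new or still open speak of the compounds shown alone.

Measured compounds:
- compound 1, `CC(=O)Nc1ccc(S(=O)(=O)NNC(=O)c2cccnc2Nc2ccc(Cl)cc2)cc1`: > 100000 nM
- compound 2, `O=C(NNS(=O)(=O)c1ccc(F)cc1)c1cccnc1Nc1ccc(Cl)cc1Cl`: > 100000 nM

Both compounds were tested in a functional assay on HCC 2998 cells (Homo sapiens) for antiproliferative activity; on this read-out higher numbers stand for lower toxicity in this test and lower numbers for higher toxicity in this test. For compound 1 the result is a limit of the test and not a number: in this assay compound 1 gives > 100000 nM. For compound 2 the result is likewise only a limit: compound 2 gives > 100000 nM. So compound 1 stands at the limit of > 100000 nM in this assay, at which 2 of the 2 values shown sit, and nothing in these data places either compound at a definite point.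

The compound not yet measured is compound 3, `O=C(NNS(=O)(=O)c1ccc(Cl)cc1Cl)c1cccnc1Nc1ccc(Cl)cc1`. It differs from compound 1 in one place only: 2,4-dichlorophenyl in place of 4-acetamidophenyl on a sulfonyl sulfur. For the measured compounds named here, no pair of measured compounds differs in a single place, so no measured step shows how such a change moves the read-out, and compound 1 itself offers only a limit to start from.

The step in this assay is therefore expected to be none beyond the scatter, and the estimated step is a number no higher from compound 1 to compound 3 (the limit leaves the size open). Compound 3 is expected to give about 100000 nM in this assay, with a range from 30000 nM to 300000 nM, most likely again reported only as a limit.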

Compound 3, concentration lethal to 50% of the cells: 61700 nM
Beside the measured number, compound 3's estimate is 1.6-fold (0.21 log units) above it, and the stated range covers the measured number.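

In this assay compound 3 gives 61700 nM, a definite number, which shows that a change on the sulfonyl sulfur alone can bring this series within the measurable range of the test. Placing 2,4-dichlorophenyl where 4-acetamidophenyl stood gives an at least 1.6-fold lower number from compound 1 to compound 3 (0.20 log units; that floor lies within the scatter); the result for compound 1 is only a limit, so the true step may be larger, but this floor alone does not establish a change beyond the usual scatter. Even if the step is real, compound 3 remains a weakly toxic compound on this read-out, and the set as a whole still offers little to measure against: the limit of > 100000 nM in this assay, at which 2 of the 3 values shown sit.

The compounds shown leave open which part of the change matters, the loss of the acetamido group or the arrival of the two chlorine atoms, and a plain phenyl ring on the sulfonyl sulfur would help to separate these two. Going by these compounds, how an amine or a carboxylic acid on that ring would read in this assay also remains open.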